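The source may hold more compounds than are shown below. What is called first, only, known or untested is meant among the compounds shown, and "the series" means these compounds.

Of the compounds shown here, three sharing one core have been measured in an assay on isolated protein for inhibition of thyroid hormone receptor beta (Homo sapiens), read by fluorescence, with a stated time of 30 min; a higher number here means a weaker inhibitor, a lower number a stronger inhibitor. Compound 1 `COc1cc(C(=O)N2CCC(O)C(C)C2)cc2nc(NCc3cncc(Cl)c3)oc12` gives 7200 nM, and compound 2 `COc1cc(C(=O)N2CCC(O)C(C)C2)cc2nc(NCc3ccnc(Cl)c3)oc12` gives 6900 nM; the step of a 1.0-fold lower number from compound 1 to compound 2 (0.02 log units; within the scatter) lies within the scatter, so these two cannot be told apart. Compound 3 `COc1cc(C(=O)N2CCC(O)C(C)C2)cc2nc(NCc3cc(Cl)ccc3O)oc12` gives 170 nM, the lowest of the three numbers, and both steps towards it, a 42-fold lower number from compound 1 to compound 3 (1.63 log units; beyond the scatter) and a 41-fold lower number from compound 2 to compound 3 (1.61 log units; beyond the scatter), are large and beyond the scatter, which makes compound 3 the strongest inhibitor measured so far.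

Compound 4 `COc1cc(C(=O)N2CCC(O)C(C)C2)cc2nc(N[C@@H](C)c3cccc(Cl)c3)oc12` has not yet been measured. It differs from compound 3 by 1-(3-chlorophenyl)ethyl in place of 5-chloro-2-hydroxybenzyl on a nitrogen on an aromatic ring. The group that leaves carries one hydrogen-bond donor and one hydrogen-bond acceptor; the group that enters carries none of either and brings one defined stereocentre. The measured steps that bear on this change are the two that reach compound 3: the large step of a 42-fold lower number from compound 1 to compound 3 (1.63 log units; beyond the scatter) and the large step of a 41-fold lower number from compound 2 to compound 3 (1.61 log units; beyond the scatter), both of which separate compound 3 from partners that also lack the hydroxyl group. Neither partner is a close match to the entering group, so the comparison is indirect. The expectation is nonetheless a clear rise in the number, estimated as a 12-fold higher number from compound 3 to compound 4 (1.07 log units; beyond the scatter). For compound 4 the estimated value in this assay is 2000 nM, with a range from 500 nM to 8000 nM.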

Compound 4, half-maximal inhibitory concentration: 5100 nM
Estimate against measurement, compound 4: 2.6-fold (0.41 log units) below; measured number inside the range.
By their numbers in this assay, from the lowest: compound 3; then compounds 4, 2 and 1 (each within the scatter of the next).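

In this assay, a carbon-only aromatic ring bearing chlorine is not enough to keep the strength of compound 3 (a 30-fold higher number from compound 3 to compound 4 (1.48 log units; beyond the scatter)), so the weakness of compounds 1 and 2 cannot be put down simply to their pyridine rings. Compound 4 instead falls level with both pyridine compounds (a 1.4-fold lower number from compound 2 to compound 4 (0.13 log units; within the scatter); a 1.4-fold lower number from compound 1 to compound 4 (0.15 log units; within the scatter)), which leaves compound 3, the only one of the four with a hydroxyl group on this ring, as the strongest inhibitor measured. This fits a link between that hydroxyl group and the lower number, but it does not prove one, and nothing measured here gives a reason for the large step.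

The change to compound 4 removes the hydroxyl group, moves the chlorine and adds a branching methyl group with a defined stereocentre, so these contributions cannot be separated, and the mirror-image form of the 1-(3-chlorophenyl)ethyl group remains an open question. A 5-chlorobenzyl group would test the loss of the hydroxyl group alone, while a 5-chloro-2-methoxybenzyl group would show whether a free hydroxyl hydrogen matters or whether any oxygen there is sufficient.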